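The source may hold more compounds than are shown below. What is called first, only, known or untested is meant among the compounds shown, and "the series" means these compounds.

Measured so far:
compound 1 `NC1(CCn2cc(F)c(=O)[nH]c2=O)OC(=O)C(OCc2ccccc2)=C1OCc1ccccc1` gives 42800 nM in a functional assay on HepG2 cells (Homo sapiens) for inhibition, read by MTT assay, with a stated time of 72 h; a lower number here means a stronger inhibitor, a higher number a weaker inhibitor;
compound 2 `O=C1O/C(=C\Cn2ncc(=O)[nH]c2=O)C(OCc2ccccc2)=C1OCc1ccccc1` gives 41300 nM in this assay.

Compound 1 holds the higher of the two numbers, but its gap to compound 2 lies within the scatter, so the two are read as alike. Compound 3 `Cc1cn(CCC2(N)OC(=O)C(OCc3ccccc3)=C2OCc2ccccc2)c(=O)[nH]c1=O` differs from compound 1 by one change: methyl in place of fluoro on an aromatic carbon. Within the data shown here, no measured pair shows what this change does. Among the measured compounds shown here, the step of a 2.0-fold higher number from compound 1 to compound 3 (0.30 log units; within the scatter) is expected to be a weakening, because compound 1 already sits at 42800 nM and nothing among the measured compounds points the other way. Compound 3 is therefore estimated at 85000 nM, with a range from 30000 nM to 250000 nM.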

Compound 3, half-maximal inhibitory concentration: > 100000 nM
Compound 3: only a limit was reported (the forecaster's own chance of this, stated with the estimate: 35%); middle value at least 1.1-fold (0.07 log units) away from the limit.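

Methyl in place of fluoro on an aromatic carbon brings an at least 2.3-fold higher number from compound 1 to compound 3 (0.36 log units; beyond the scatter) in this assay, the first sign that this position responds to the group it carries. Compound 3 is reported only as a limit (> 100000 nM). The full size of the step therefore stays unknown, and the data mark only its lower bound: the limit of > 100000 nM in this assay, at which 1 of the 3 values shown sits.

The compounds shown leave open how chloro, an amine or a longer chain would behave at this carbon. Also open, from the compounds shown here alone, is whether the step would hold on a core other than that of compound 1.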